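Swapping Ethyl for Cyclopropyl on a Sulfonyl Group

The compounds below may be only part of what the source reports. "The series", "measured", "known", "first", "only" and "open" are said of these compounds alone.

Compound 1, `CC(O)(C#Cc1cccc(Nc2ncnc3[nH]ccc23)c1)c1nccs1` — in an assay for inhibition of mitogen-activated protein kinase kinase kinase 14 (Homo sapiens), read by luminescence and ADP-Glo, with a stated time of 120 min, in the presence of a further agent that is not named here (on this read-out higher numbers stand for weaker inhibition and lower numbers for stronger inhibition), compound 1 gives 1640 nM
Compound 2, `CC(O)(C#Cc1ccc(N2CC3CC2CN3)c(Nc2ncnc3[nH]ccc23)c1)c1nccs1` — compound 2 gives 200 nM
Compound 3, `CCS(=O)(=O)N1CCN(c2ccc(C#CC(C)(O)c3nccs3)cc2Nc2ncnc3[nH]ccc23)CC1` — compound 3 gives 8.22 nM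

Compound 3 stands lowest of the three numbers: a 24-fold lower number from compound 2 to compound 3 (1.39 log units; beyond the scatter) and a 200-fold lower number from compound 1 to compound 3 (2.30 log units; beyond the scatter). Compound 4, `CC(O)(C#Cc1ccc(N2CCN(S(=O)(=O)C3CC3)CC2)c(Nc2ncnc3[nH]ccc23)c1)c1nccs1`, keeps all of compound 3 and changes one part: cyclopropyl in place of ethyl on a sulfonyl sulfur. Going by the values given here, none of the measured steps touches this sulfonyl substituent; the steps of an 8.2-fold lower number from compound 1 to compound 2 (0.91 log units; beyond the scatter) and a 200-fold lower number from compound 1 to compound 3 (2.30 log units; beyond the scatter) concern the whole group on the aromatic carbon, not its outer end. With no direct guide for this small swap, the step of a 1.0-fold lower number from compound 3 to compound 4 (0.01 log units; within the scatter) is expected to lie within the scatter. The estimate for compound 4 is 8 nM, ranging from 3 nM to 25 nM.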

Compound 4, half-maximal inhibitory concentration: 16.2 nM
Estimate against measurement, compound 4: 2.0-fold (0.31 log units) below; low and high end bracket the measured number.
By their numbers in this assay, from the lowest: compounds 3 and 4 (each within the scatter of the next); then compound 2; then compound 1.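

In this assay, cyclopropyl can stand in place of ethyl on the sulfonyl sulfur with no change beyond the scatter (a 2.0-fold higher number from compound 3 to compound 4 (0.29 log units; within the scatter)). Going by these compounds alone, the large distance from the earlier compounds also holds with the new group (a 12-fold lower number from compound 2 to compound 4 (1.09 log units; beyond the scatter); a 100-fold lower number from compound 1 to compound 4 (2.01 log units; beyond the scatter)), so it does not depend on ethyl alone. Nothing available explains these numbers. From the compounds shown here alone, whether a much larger group on the same sulfur, such as phenyl, would keep the number stays open. So does whether the sulfonyl group itself is needed.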